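The source may report more compounds than this note shows. Statements on the series, on what has been measured and on what is new or still open speak of the compounds shown alone.

In a functional assay on HL-60 cells (Homo sapiens) for cytotoxicity, read by WST assay, with a stated time of 48 h (on this read-out higher numbers stand for an effect only at larger amounts of compound and lower numbers for an effect already at smaller amounts), compound 1, `COc1ccc(C[C@H]2C(=O)OC[C@@H]2Cc2ccccc2)cc1`, gives 67000 nM. Compound 2, `Cc1ccc(C[C@H]2C(=O)OC[C@@H]2Cc2ccccc2)cc1`, differs from compound 1 by methyl in place of methoxy on an aromatic carbon; in this assay compound 2 gives 44000 nM, and the step of a 1.5-fold lower number from compound 1 to compound 2 (0.18 log units; within the scatter) is within the scatter, so the two values show no real separation. Compound 3, `COc1ccc(C[C@H]2COC(=O)[C@@H]2Cc2ccc(Cl)c(Cl)c2)cc1`, is built on another core; the difference between the cores of compound 1 and compound 3 is not broken down here. In this assay compound 3 gives 37000 nM, a value that stays within the scatter of those of compound 1 and compound 2. Compound 4, `Cc1ccc(C[C@H]2COC(=O)[C@@H]2Cc2ccc(Cl)c(Cl)c2)cc1`, differs from compound 3 by methyl in place of methoxy on an aromatic carbon, the same change that leads from compound 1 to compound 2, at the same kind of place. Compound 4 has not yet been measured in this assay. Because the step of a 1.5-fold lower number from compound 1 to compound 2 (0.18 log units; within the scatter) stayed within the scatter, compound 4 is expected to show a step of a 1.2-fold lower number from compound 3 to compound 4 (0.09 log units; within the scatter). For compound 4 the estimate in this assay is 30000 nM, with a range from 12000 nM to 70000 nM.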

Compound 4, half-maximal effective concentration: 19000 nM
The estimate for compound 4 lay 1.6-fold (0.20 log units) above the measured number, and the stated range covers the measured number.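

In this assay, methyl in place of methoxy on an aromatic carbon gives a 1.9-fold lower number from compound 3 to compound 4 (0.29 log units; within the scatter), so this pair, like the first, shows no real separation. Set beside the earlier step, the change reads the same on both cores: the same change on two cores in this assay, a 1.5-fold lower number (0.18 log units; within the scatter) from compound 1 to compound 2 and a 1.9-fold lower number (0.29 log units; within the scatter) from compound 3 to compound 4, 1.3-fold (0.11 log units) apart, within the scatter of two such steps. This shows that the change carried from one core to the other without a step beyond the scatter on either, but it does not show that the change has any real effect on this read-out, and two pairs say nothing about how it would behave on a further core.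

The compounds shown hold only methoxy or methyl at this place, para to a large group, which leaves open what an amine, a carboxylic acid or a longer chain would do there. Also open is how much the two chlorine atoms of compound 3 and compound 4 contribute, as no pair shown isolates them from the change of core.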